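Fluoro for hydrogen across two matched pairs

The compounds below may be only part of what the source reports. "The series", "measured", "known", "first", "only" and "open" are said of these compounds alone.

Compound 1 `Cn1cnc2c(Sc3ccccc3)ncnc21` and compound 2 `Cn1cnc2c(Sc3ccc(F)cc3)ncnc21` share one core. In an assay on isolated protein for inhibition of Ca2+/calmodulin-dependent protein kinase II (CaM kinase II) (Rattus norvegicus), tested at 30 uM (a lower number here means less inhibition, a higher number more inhibition at the concentration tested (going by the name of the read-out)), compound 1 gives 8%, and compound 2 gives 5%. The change between them is fluoro in place of hydrogen on an aromatic carbon, and the step it made is a number 3 percentage points lower from compound 1 to compound 2 (within the scatter). Compound 3 `Clc1ncnc2c1ncn2Cc1ccccc1` carries a different core; how the two cores differ is not broken down here. In this assay compound 3 gives 7%, close to both earlier numbers. Compound 4 `Fc1ccc(Cn2cnc3c(Cl)ncnc32)cc1` is not yet measured and differs from compound 3 by fluoro in place of hydrogen on an aromatic carbon, the same change made once more. The expected step in this assay is a number 2 percentage points lower from compound 3 to compound 4 (within the scatter), which rests on a number 3 percentage points lower from compound 1 to compound 2 (within the scatter) and on the low numbers seen so far. Compound 4 is expected to give 5% in this assay, estimated between -5% and 15%.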

Compound 4, a percentage reported as inhibition, at one concentration (the size of the read-out at that concentration, not a potency): 0%
Compound 4: the middle estimate sits 5 percentage points above what was measured; the measured number falls inside the stated range.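

In this assay, fluoro in place of hydrogen on an aromatic carbon, para to a large group, gives a number 7 percentage points lower from compound 3 to compound 4 (within the scatter). Set beside the earlier step, the change reads alike on the two cores: the same change on two cores in this assay, a number 3 percentage points lower (within the scatter) from compound 1 to compound 2 and a number 7 percentage points lower (within the scatter) from compound 3 to compound 4, 4 percentage points apart, within the scatter of two such steps. Neither step stands clear of the scatter, and with all the numbers this low, the two pairs show no difference between cores but do not show that the change would carry over to a compound with marked inhibition.

Left open is what fluoro does on a core that gives a high number at the concentration tested. Also open, as far as these compounds go, is what an amine or a carboxylic acid would give in place of the fluoro, on either core.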